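This account rests on a few compounds, and the source may have more. Where it says the series, first, only, none or still open, it means among the compounds named here.

Measured so far, in a functional assay on U-251 cells (Homo sapiens) for inhibition, read by sulforhodamine B assay, with a stated time of 48 h; on this read-out lower numbers stand for higher toxicity in this test and higher numbers for lower toxicity in this test: compound 1 `Nc1cc(N)c2nc(-c3ccccc3)c(Oc3ccc(Cl)c(Cl)c3)nc2c1` gives 83200 nM; compound 2 `Nc1cc(N)c2nc(-c3ccccc3)c(NCc3ccc(F)cc3)nc2c1` gives 6310 nM. For compound 3 `Nc1cc(N)c2nc(-c3ccccc3)c(Oc3ccc(F)cc3)nc2c1` this assay gives only a limit, < 100000 nM, as recorded in the limit of < 100000 nM in this assay, at which 1 of the 3 values shown sits.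

Among the measured steps, a 13-fold lower number from compound 1 to compound 2 (1.12 log units; beyond the scatter) is the only one with a readable size; a step that the limit leaves unreadable from compound 1 to compound 3 and a step that the limit leaves unreadable from compound 2 to compound 3 stay unreadable, so compound 3 stands only as a limit and not as a number.

Compound 4 `Nc1cc(N)c2nc(-c3ccccc3)c(Sc3ccc(F)cc3)nc2c1` differs from compound 3 by (4-fluorophenyl)sulfanyl in place of 4-fluorophenoxy on an aromatic carbon. Among the compounds with values here, none of the measured steps follows this exchange of oxygen for sulfur, so nothing argues for a step beyond the scatter; compound 4 is expected to sit close to compound 3, giving a step that the limit leaves unreadable from compound 3 to compound 4. Compound 4 is estimated at 60000 nM, within 15000 nM to 200000 nM.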

Compound 4, concentration lethal to 50% of the cells: 61700 nM
Beside the measured number, compound 4's estimate is 1.0-fold (0.01 log units) below it; the range from low to high includes it.
By their numbers in this assay, from the lowest: compound 2; then compounds 4 and 1 (each within the scatter of the next).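

Within the data shown here, compound 4 gives the first readable number for (4-fluorophenyl)sulfanyl on this aromatic carbon in this assay, but its exchange for 4-fluorophenoxy cannot be read, since compound 3 stands only as a limit: the limit of < 100000 nM in this assay, at which 1 of the 4 values shown sits.
Putting (4-fluorophenyl)sulfanyl in place of (4-fluorobenzyl)amino gives a 9.8-fold higher number from compound 2 to compound 4 (0.99 log units; beyond the scatter), while putting it in place of 3,4-dichlorophenoxy gives a 1.3-fold lower number from compound 1 to compound 4 (0.13 log units; within the scatter), so among the three numbers only compound 2 stands apart.

Going by these compounds, it remains open whether that gap follows the nitrogen link or the extra benzyl carbon; 4-fluoroanilino and (4-fluorobenzyl)oxy groups at this position would separate the two.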